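This account rests on a few compounds, and the source may have more. Where it says the series, first, only, none or still open, it means among the compounds named here.

Compound 1 `O=c1[nH]c(Nc2cccc(F)c2)nc2cc(Cl)ccc12`: > 25000 nM (a limit)
Compound 2 `O=c1[nH]c(Nc2cc(Cl)cc(Cl)c2)nc2cc(Cl)ccc12`: > 25000 nM (a limit)

In an ADME assay on Vero cells (Chlorocebus sabaeus) for cytotoxicity, read by WST assay (a lower number here means that less compound is tolerated, a higher number that more compound is tolerated), compound 2 gives > 25000 nM, which is a limit of the assay and not a number. Compound 1 gives > 25000 nM, again a limit. Neither compound therefore has a measured number, and the only mark on the scale is the limit of > 25000 nM in this assay, at which 2 of the 2 values shown sit.

Compound 3 `Nc1ccc2c(=O)[nH]c(Nc3cc(Cl)cc(Cl)c3)nc2c1` has not yet been measured. It carries amino in place of chloro on an aromatic carbon of the shared core: amino in place of chloro on an aromatic carbon. Within the data shown here, no step between measured compounds is available to size this change in this assay, so the expectation rests on little. Compound 2 gives > 25000 nM, a limit, and that is its main ground. The expected size is a number no higher from compound 2 to compound 3 (the limit leaves the size open), with no change beyond the scatter anticipated. A further limit is the likelier outcome, and if a number does appear, a lower one is expected. For compound 3 the estimate is 25000 nM, with an expected range from 12000 nM to 30000 nM.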

Compound 3, half-maximal cytotoxic concentration: > 25000 nM
Compound 3: a limit, no number; the forecaster's own chance of this, stated with the estimate: 70%; the middle value sits exactly at the limit.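

No size can be read for amino in place of chloro between compound 2 and compound 3 in this assay, because both give a limit and not a number: the limit of > 25000 nM in this assay, at which 3 of the 3 values shown sit.

The compounds shown leave open at what concentration any of them becomes cytotoxic, and whether this change shifts that concentration at all.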